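A few compounds are considered here, and "the series" means these few. Any claim that something is new, unique, unknown or untested is made for them only; others in the source may bear on it.

In a functional assay for activation of Alpha-1D adrenergic receptor (Homo sapiens), read by calcium flux (on this read-out higher numbers stand for an effect only at larger amounts of compound and lower numbers for an effect already at smaller amounts), compound 1 `c1cncc(-c2ccccc2OCC2=NCCN2)c1` gives 158 nM and compound 2 `c1ccc(-c2ccns2)c(OCC2=NCCN2)c1` gives 25.1 nM. The only difference between them is the five-membered ring attached to the shared core, and this step, a 6.3-fold lower number from compound 1 to compound 2 (0.80 log units; beyond the scatter), is recorded as beyond the usual scatter. Compound 3 `c1ccc(-c2ncc[nH]2)c(OCC2=NCCN2)c1`, which carries a 1H-imidazol-2-yl in the same position, stands apart: in this assay compound 3 gives < 100000 nM, which is a limit of the assay and not a number. Because of the limit of < 100000 nM in this assay, at which 1 of the 3 values shown sits, the steps a step that the limit leaves unreadable from compound 1 to compound 3 and a step that the limit leaves unreadable from compound 2 to compound 3 cannot be read, and compound 3 cannot be placed against the other two. Compound 4 `Cc1csc(-c2ccccc2OCC2=NCCN2)n1` is not yet measured. It differs from compound 3 by 4-methyl-1,3-thiazol-2-yl in place of 1H-imidazol-2-yl on an aromatic carbon, on an aromatic carbon of a six-membered aromatic ring of carbon only, ortho to a group of 7 heavy atoms. The 4-methyl-1,3-thiazol-2-yl that enters resembles the 1,2-thiazol-5-yl of compound 2, which gives 25.1 nM, more than it resembles the ring of compound 3, so compound 4 is expected to give a number rather than a limit. The step that the limit leaves unreadable from compound 3 to compound 4 cannot be judged against the unreadable steps and is only an expectation. Compound 4 is estimated at 50 nM, with a range from 10 nM to 300 nM.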

Compound 4, half-maximal effective concentration: < 100000 nM
Compound 4: only a limit was reported; the forecaster's own chance of this, stated with the estimate: 15%; the middle value is on the limit's open side.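

In this assay compound 4 gives < 100000 nM, which is a limit of the assay and not a number. No step from compound 1, compound 2 or compound 3 to compound 4 can be read, because the comparison runs into this limit: the limit of < 100000 nM in this assay, at which 2 of the 4 values shown sit.

The compounds shown leave open whether compound 3 and compound 4 differ at all in this assay, and what separates these two from compound 1 and compound 2.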